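One Cyano Less on Two Related Cores

The source may hold more compounds than are shown below. What is called first, only, known or untested is meant among the compounds shown, and "the series" means these compounds.

Compound 1 `N#Cc1ccccc1-c1nc2cccnc2o1` and compound 2 `c1ccc(-c2nc3cccnc3o2)cc1` share a core and differ by hydrogen in place of cyano on an aromatic carbon. In a functional assay on the whole organism for inhibition, with Rattus norvegicus as the target, at a dose of 30 mg/kg (on this read-out lower numbers stand for less inhibition and higher numbers for more inhibition at the one dose given (going by the name of the read-out)), compound 1 gives 61%, and compound 2 gives 55%, so a number 6 percentage points lower from compound 1 to compound 2 (within the scatter). Compound 3 `N#Cc1cccc(C#N)c1-c1nc2ncccc2o1` carries two cyano groups on another core; the difference between the two cores is not broken down here. In this assay compound 3 gives 19%, the lowest of the three numbers. Compound 4 `N#Cc1ccccc1-c1nc2ncccc2o1` is not yet measured and differs from compound 3 by hydrogen in place of cyano on an aromatic carbon, the same kind of change as that between compound 1 and compound 2, though here the place is also meta to a cyano group. Because the earlier step of a number 6 percentage points lower from compound 1 to compound 2 (within the scatter) was small, only a modest rise is expected for compound 4, an estimated step of a number 16 percentage points higher from compound 3 to compound 4 (beyond the scatter). Compound 4 is therefore expected to give about 35%, somewhere between 10% and 65%.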

Compound 4, a percentage reported as inhibition, in the whole organism at one dose (the size of the read-out at that dose, not a potency): 62%
Estimate against measurement, compound 4: 27 percentage points below; measured number inside the range.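

In this assay, hydrogen in place of cyano gives a number 43 percentage points higher from compound 3 to compound 4 (beyond the scatter). The size of this change therefore does not carry over unchanged from one core to the other: the same change on two cores in this assay, a number 6 percentage points lower (within the scatter) from compound 1 to compound 2 and a number 43 percentage points higher (beyond the scatter) from compound 3 to compound 4, 49 percentage points apart, beyond the scatter of two such steps. This shows that, within these two pairs, a step read on one core is a poor guide to the step on the other, but it does not show why, since the position meta to a cyano group occurs only in the second pair, so the core and that second cyano group cannot be told apart.

On these data alone, it remains open what a second cyano group would do on the core of compound 1. As far as these compounds go, it is also open whether an amine or a carboxylic acid in place of cyano would follow either step.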